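The compounds below may be only part of what the source reports. "The series", "measured", "known", "first", "only" and "open" are said of these compounds alone.

Measured compounds:
- Compound 1, `CC(C)NC(=O)NC1CC(C)(C)Oc2ccc(Cl)cc21`: in a functional assay on T98G cells (Homo sapiens) for inhibition, read by MTT assay, with a stated time of 72 h (on this read-out lower numbers stand for stronger inhibition and higher numbers for weaker inhibition), compound 1 gives > 100000 nM, which is a limit of the assay and not a number.
- Compound 2, `CC1(C)CC(NC(=O)Nc2ccccc2)c2cc(Cl)ccc2O1`: in this assay compound 2 gives 34000 nM.
- Compound 3, `CC(=O)NC1CC(C)(C)Oc2ccc(Cl)cc21`: in this assay compound 3 shows "not determined" (no result reported), so no number is known for it.

Compound 3 therefore stands nowhere on the numbers shown; the only anchors are compound 1 at its limit of > 100000 nM in this assay, at which 1 of the 3 values shown sits, and compound 2 with a real number. Compound 4, `CC1(C)CC(NC(=O)Nc2ccccc2Cl)c2cc(Cl)ccc2O1`, differs from compound 3 in one place: (2-chlorophenyl)amino in place of methyl on a carbonyl carbon. Among the compounds with values here, the one measured step that bears on this, an at least 2.9-fold lower number from compound 1 to compound 2 (0.46 log units; beyond the scatter), also brings an aromatic ring onto the urea part and gives a lower number, at least modest in size. Within the data shown here, since compound 3 has no number, no step from it can be sized; the expectation for compound 4 rests on compound 2, whose value 34000 nM comes from the closest measured structure. Compound 4 is estimated at 20000 nM, within a range from 5000 nM to 100000 nM.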

Compound 4, half-maximal inhibitory concentration: 20000 nM
The estimate for compound 4 equals the measured number at the digits printed, within the range that was stated.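

In this assay, chloro in place of hydrogen on an aromatic carbon gives a 1.7-fold lower number from compound 2 to compound 4 (0.23 log units; within the scatter), so at this position the added chlorine shows no change that can be told apart from the usual spread of repeated measurements. Setting 2-chlorophenyl in place of isopropyl on an amide-type nitrogen gives an at least 5.0-fold lower number from compound 1 to compound 4 (0.69 log units; beyond the scatter), so the step that stands clear of the scatter is the one that brings in the aromatic ring, not the one that adds the chlorine. This step is only a lower bound, since the value of compound 1 is a limit of the assay and not a number: the limit of > 100000 nM in this assay, at which 1 of the 4 values shown sits.

The step from compound 3 cannot be read. From the compounds shown here alone, how an amine or a carboxylic acid in place of this chloro would read remains open.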